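The source may report more compounds than this note shows. Statements on the series, on what has been measured and on what is new or still open speak of the compounds shown alone.

Compound 1 `CCCCCCCCC(CCO)n1cnc2c(Cl)ncnc21` and compound 3 `CCCCCCCCCC(CCO)n1cnc2c(Cl)ncnc21` share a core and differ by methyl in place of hydrogen on a saturated chain carbon, nine bonds along the chain from an aromatic nitrogen. In a functional assay on SW480 cells (Homo sapiens) for antiproliferative activity, read by MTT assay, with a stated time of 48 h (on this read-out lower numbers stand for stronger inhibition and higher numbers for weaker inhibition), compound 1 gives 1370 nM, and compound 3 gives 1150 nM; the step of a 1.2-fold lower number from compound 1 to compound 3 (0.08 log units; within the scatter) lies within the scatter, so the two are not told apart by this read-out. Compound 2 `CCCCCCCCC(CCO)n1c(Br)nc2c(Cl)ncnc21` arises from compound 1 by bromo in place of hydrogen on an aromatic carbon. In this assay compound 2 gives 17800 nM, which amounts to a step of a 13-fold higher number from compound 1 to compound 2 (1.11 log units; beyond the scatter). Compound 4 `CCCCCCCCCC(CCO)n1c(Br)nc2c(Cl)ncnc21` has not yet been measured. Among the measured compounds shown here, it differs from compound 3 by bromo in place of hydrogen on an aromatic carbon, and this is the same change as the one that turns compound 1 into compound 2, now made on the core of compound 3. Because the step of a 13-fold higher number from compound 1 to compound 2 (1.11 log units; beyond the scatter) was large, and the two cores sit within the scatter of each other, a step of similar size is expected from compound 3 to compound 4. The expected step is a 13-fold higher number from compound 3 to compound 4 (1.12 log units; beyond the scatter). Compound 4 is therefore estimated at 15000 nM, with a range expected from 6000 nM to 40000 nM.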

Compound 4, half-maximal inhibitory concentration: 25000 nM
For compound 4 the middle estimate is 1.7-fold (0.22 log units) below the measured one, and the stated range covers the measured number.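

In this assay, bromo in place of hydrogen on an aromatic carbon again gives a large step on the core of compound 3, a 22-fold higher number from compound 3 to compound 4 (1.34 log units; beyond the scatter), and this step matches the earlier one on the core of compound 1: the same change on two cores in this assay, a 13-fold higher number (1.11 log units; beyond the scatter) from compound 1 to compound 2 and a 22-fold higher number (1.34 log units; beyond the scatter) from compound 3 to compound 4, 1.7-fold (0.22 log units) apart, within the scatter of two such steps

The methyl change, read on the bromo-bearing core, gives a 1.4-fold higher number from compound 2 to compound 4 (0.15 log units; within the scatter), so it does not tell the compounds apart on either core: the same change on two cores in this assay, a 1.2-fold lower number (0.08 log units; within the scatter) from compound 1 to compound 3 and a 1.4-fold higher number (0.15 log units; within the scatter) from compound 2 to compound 4, 1.7-fold (0.22 log units) apart, within the scatter of two such steps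

These two pairs show that each change carried over between two cores differing only by that one methyl, but they do not show that the bromo step would hold on cores that differ more, and they give no reason for its size.

The compounds shown leave open whether an amine or chloro in place of the bromo on that aromatic carbon would give a step of like size. They also leave open how the bromo step behaves on a core carrying a much shorter chain or a carboxylic acid.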